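Extending the Ester Chain of Compound 2

The source may hold more compounds than are shown below. What is called first, only, known or untested is meant among the compounds shown, and "the series" means these compounds.

Among the compounds with values here, compound 2 `CCC(=O)Oc1cc(C(=O)C2=C3OC(C)(C)[C@@H](CC=C(C)C)C[C@@]34C[C@@H](CC=C(C)C)C(C)(C)[C@H]3CCC(C)(C)O[C@]34OC2=O)ccc1O` is the one member of this small set with a number in a functional assay on K562 cells (Homo sapiens) for antiproliferative activity, read by MTT assay, with a stated time of 72 h; on this read-out lower numbers stand for stronger inhibition and higher numbers for weaker inhibition: compound 2 gives 12100 nM. Compound 1 `CCC(=O)Oc1ccc(C(=O)C2=C3OC(C)(C)[C@@H](CC=C(C)C)C[C@@]34C[C@@H](CC=C(C)C)C(C)(C)[C@H]3CCC(C)(C)O[C@]34OC2=O)cc1OC(=O)CC` reaches only the limit of the assay, > 20000 nM in this assay. Compound 3 `CC(C)=CC[C@H]1C[C@]23C[C@@H](CC=C(C)C)C(C)(C)[C@H]4CCC(C)(C)O[C@]42OC(=O)C(C(=O)c2ccc(OC(=O)c4ccc(F)cc4)c(OC(=O)c4ccc(F)cc4)c2)=C3OC1(C)C` likewise reaches only the limit, > 20000 nM. Within the data shown here, the single step measured in one place is an at least 1.6-fold lower number from compound 1 to compound 2 (0.21 log units; that floor lies within the scatter); it starts from the limit of > 20000 nM in this assay, at which 2 of the 3 values shown sit, so its true size is not known.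

Compound 4 `CCCCCC(=O)Oc1cc(C(=O)C2=C3OC(C)(C)[C@@H](CC=C(C)C)C[C@@]34C[C@@H](CC=C(C)C)C(C)(C)[C@H]3CCC(C)(C)O[C@]34OC2=O)ccc1O` differs from compound 2 by propyl in place of hydrogen on a saturated chain carbon, two bonds along the chain from a carbonyl carbon. Among the measured compounds shown here, no measured step touches the length of the ester chain; the step from compound 1 to compound 2 concerns the presence of the ester, not its extension, and the two limits give no direction. Compound 4 is therefore expected to show a 1.2-fold higher number from compound 2 to compound 4 (0.09 log units; within the scatter), a step not beyond the scatter. Compound 4 is estimated at 15000 nM, with a range from 6000 nM to 40000 nM in this assay, and a real chance that only a limit is reported.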

Compound 4, half-maximal inhibitory concentration: 13500 nM
The estimate for compound 4 lay 1.1-fold (0.05 log units) above the measured number; the range from low to high includes it.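

Putting propyl in place of hydrogen on the saturated chain carbon, two bonds along the chain from a carbonyl carbon, gave in this assay a 1.1-fold higher number from compound 2 to compound 4 (0.05 log units; within the scatter). Within the data shown here, this is the first measured change to the length of the ester chain, and it shows that going from propanoyl to pentylcarbonyl at this place leaves the two compounds indistinguishable in this read-out. Unlike the earlier step, this one runs between two numbers rather than from a limit, so its size can be read.

From the compounds shown here alone, whether a longer chain, an amine or a carboxylic acid in this place would move the number beyond the scatter remains open. Also open is the true size of the step that puts hydrogen in place of propanoyl on the aromatic oxygen, as that step starts from a limit: the limit of > 20000 nM in this assay, at which 2 of the 4 values shown sit.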